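Methoxy Added to the Longer Chain: Expected Cytotoxicity

A few compounds are considered here, and "the series" means these few. Any claim that something is new, unique, unknown or untested is made for them only; others in the source may bear on it.

Three compounds have been measured in an ADME assay on RD cells (Homo sapiens) for cytotoxicity, read by MTT assay, with a stated time of 3 days; on this read-out higher numbers stand for lower toxicity in this test and lower numbers for higher toxicity in this test:

- compound 1, `CC[C@@H](CCn1cncn1)c1ccccc1`, gives 91.2 ug/mL
- compound 2, `CC[C@@H](CCn1cncn1)c1ccc(OC)cc1`, gives 115 ug/mL
- compound 3, `CCCC[C@@H](CCn1cncn1)c1ccccc1`, gives 47.5 ug/mL

Compound 3 gives the lowest of the three numbers, but its gap to compound 1 is within the scatter, and only compound 2 lies beyond it. Two single changes connect the measured compounds. Placing methoxy on the aromatic carbon gave a 1.3-fold higher number from compound 1 to compound 2 (0.10 log units; within the scatter). Replacing a hydrogen of the chain with ethyl gave a 1.9-fold lower number from compound 1 to compound 3 (0.28 log units; within the scatter). Neither change moved the read-out beyond the scatter.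

Compound 4, `CCCC[C@@H](CCn1cncn1)c1ccc(OC)cc1`, has not yet been measured. It differs from compound 3 as follows: methoxy in place of hydrogen on an aromatic carbon. This is the same change as the step from compound 1 to compound 2, which did not leave the scatter, so no real shift is expected in this assay, at most a slightly higher number. Compound 4 is therefore estimated at 60 ug/mL, in a range from 30 ug/mL to 120 ug/mL. The expected step from compound 3 is a 1.3-fold higher number from compound 3 to compound 4 (0.10 log units; within the scatter), small enough to count as no change.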

Compound 4, half-maximal cytotoxic concentration: 39.4 ug/mL
Compound 4: the middle estimate sits 1.5-fold (0.18 log units) above what was measured; the measured number falls inside the stated range.
By their numbers in this assay, from the lowest: compounds 4, 3, 1 and 2 (each within the scatter of the next, the first and the last beyond it).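

On the core of compound 3, methoxy in place of hydrogen on an aromatic carbon, para to a large group, again leaves the number in this assay within the scatter, with a 1.2-fold lower number from compound 3 to compound 4 (0.08 log units; within the scatter). The methoxy change now has two examples, and they agree with each other: the same change on two cores in this assay, a 1.3-fold higher number (0.10 log units; within the scatter) from compound 1 to compound 2 and a 1.2-fold lower number (0.08 log units; within the scatter) from compound 3 to compound 4, 1.5-fold (0.18 log units) apart, within the scatter of two such steps. Ethyl in place of hydrogen on the saturated chain carbon, now read with methoxy present, gives a 2.9-fold lower number from compound 2 to compound 4 (0.47 log units; beyond the scatter), a modest step beyond the scatter and so a real move towards higher toxicity in this test, yet the two ethyl steps cannot be told apart, so methoxy cannot be said to strengthen the ethyl effect: the same change on two cores in this assay, a 1.9-fold lower number (0.28 log units; within the scatter) from compound 1 to compound 3 and a 2.9-fold lower number (0.47 log units; beyond the scatter) from compound 2 to compound 4, 1.5-fold (0.18 log units) apart, within the scatter of two such steps.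

From the compounds shown here alone, only hydrogen and methoxy appear at this aromatic position, so it remains open whether a different group there, such as chlorine or a carboxylic acid, would move the number beyond the scatter. Going by these compounds, it also remains open whether a longer chain at the saturated carbon would take the number lower still, or whether an amine placed on that chain would reverse the step.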